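Methyl for Chloro on a Weakly Binding Hydrazone Pair

The source may report more compounds than this note shows. Statements on the series, on what has been measured and on what is new or still open speak of the compounds shown alone.

Measured so far:
compound 1, `CC(=O)/C(=N\Nc1ccccc1Cl)Sc1cccc(Cl)c1` — > 10000 nM
compound 2, `CC(=O)/C(=N\Nc1ccccc1C)N(C)c1cccc(Cl)c1` — > 10000 nM

In an assay on isolated protein for binding affinity to corticotropin-releasing factor receptor 1 (Homo sapiens) (a higher number here means a weaker inhibitor, a lower number a stronger inhibitor), compound 1 gives > 10000 nM, which is a limit of the assay and not a number. In this assay compound 2 likewise gives > 10000 nM, again a limit rather than a measured value. For the measured compounds named here, compound 1 therefore stands at the limit itself, and so does the only other compound with a result, as summarised by the limit of > 10000 nM in this assay, at which 2 of the 2 values shown sit. Going by the values given here, no step between two measured compounds can be drawn here, since neither compound has a number.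

The unmeasured compound 3, `CC(=O)/C(=N\Nc1ccccc1C)Sc1cccc(Cl)c1`, differs from compound 1 by methyl in place of chloro on an aromatic carbon. Compound 2 carries the same 2-methylphenyl group but a different link to the chlorophenyl ring, so it is not a single step from either compound.

For compound 3 the expected outcome in this assay is that it again returns only a limit, because both measured values sit at the limit of > 10000 nM in this assay, at which 2 of the 2 values shown sit. The estimate for compound 3 is 15000 nM, within a range of 5000 nM to 50000 nM, which would mean an expected step that the limit leaves unreadable from compound 1 to compound 3, none beyond the scatter.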

Compound 3, inhibition constant: > 10000 nM
Compound 3: no number, only a limit; the forecaster's own chance of this, stated with the estimate: 80%; the middle value does not contradict the limit.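

Compound 1 and compound 3 both return only limits in this assay, so the step of methyl in place of chloro on an aromatic carbon cannot be read from this pair. The compounds shown leave open how far methyl and chloro differ at this place, and whether any compound of this kind reaches a measured number: the limit of > 10000 nM in this assay, at which 3 of the 3 values shown sit.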